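Swapping the aryl ketone of a chalcone-like pyrazole

The source may report more compounds than this note shows. Statements on the series, on what has been measured and on what is new or still open speak of the compounds shown alone.

Compound 1 `COc1ccc(-c2cc(/C=C/C(=O)c3ccc(N)cc3)[nH]n2)cc1` and compound 2 `COc1cc(-c2cc(/C=C/C(=O)c3ccc(Cl)c(Cl)c3)[nH]n2)cc(OC)c1OC` share a core in which a pyrazole ring is linked through a double bond to a ketone bearing an aromatic ring. In a functional assay on SK-MEL-28 cells (Homo sapiens) for inhibition, read by sulforhodamine B assay, with a stated time of 48 h (on this read-out lower numbers stand for higher toxicity in this test and higher numbers for lower toxicity in this test), compound 1 gives 8570 nM. For compound 2 this assay reports only a limit, > 100000 nM, so compound 2 stands at the edge of what the test can measure the limit of > 100000 nM in this assay, at which 1 of the 2 values shown sits, and no number for it is known. Compound 3 `COc1ccc(C(=O)/C=C/c2cc(-c3cc(OC)c(OC)c(OC)c3)n[nH]2)cc1` keeps the rest of compound 2 and changes one place: 4-methoxyphenyl in place of 3,4-dichlorophenyl on a carbonyl carbon. Among the measured compounds shown here, no pair of measured compounds differs in exactly this way, so the size of the step cannot be read from the data. Compound 1, whose ketone also carries a single-substituted phenyl ring, gives 8570 nM, and on that basis compound 3 is expected to show greater toxicity than compound 2, a step from compound 2 to compound 3 of about an at least 2.0-fold lower number from compound 2 to compound 3 (0.30 log units; that floor lies within the scatter). Compound 3 is therefore estimated at 50000 nM, in a range from 10000 nM to 150000 nM, with a real chance that this assay again reports only a limit.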

Compound 3, concentration lethal to 50% of the cells: 9230 nM
Compound 3: middle estimate off by 5.4-fold (0.73 log units), on the high side, outside the stated range (below it).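

The earlier compounds shown here offered no measured pair for this change, and compounds 2 and 3 now provide one: on a carbonyl carbon, 4-methoxyphenyl in place of 3,4-dichlorophenyl gives an at least 10-fold lower number from compound 2 to compound 3 (1.03 log units; beyond the scatter) in this assay, which shows that the group at this place can decide whether the rest of the molecule gives a measured value at all. Compound 2 is recorded only as a limit, > 100000 nM. The step is therefore a floor and not an exact size, because compound 2 has no number of its own: the limit of > 100000 nM in this assay, at which 1 of the 3 values shown sits.

From the compounds shown here alone, this single pair cannot separate the loss of the two chlorine atoms from the arrival of the methoxy group, so it remains open whether a plain phenyl or a 4-chlorophenyl on the same carbonyl carbon would behave like compound 2 or like compound 3. Going by these compounds, it is also open how a group of a different kind at this place, such as a carboxylic acid, would fare, and whether the same swap would have a similar effect on the core of compound 1.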